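A few compounds are considered here, and "the series" means these few. Any claim that something is new, unique, unknown or untested is made for them only; others in the source may bear on it.

Compound 2, `O=C(NCc1cc(Cl)ccc1-n1cnnn1)[C@@H]1CC=NN1C(=O)[C@H](O)c1ccccc1F`, is the point from which this account sets out. In an ADME assay on liver for metabolic stability, with Liver microsome (Homo sapiens) as the target, read by LC-MS, using microsomes (a higher number here means faster removal of the compound, a lower number slower removal), compound 2 gives 16 mL.min-1.g-1, and this is the only plain number among the three results shown. Compound 1, `CC(C)(C)C[C@@H](O)C(=O)N1OCC[C@H]1C(=O)NCc1cc(Cl)ccc1-n1cnnn1`, gives in this assay < 12 mL.min-1.g-1, which is a limit rather than a number. Compound 3, `O=C(NCc1cc(Cl)ccc1-n1cnnn1)[C@@H]1[C@@H]2C[C@@H]2CN1C(=O)[C@H](O)c1ccccc1`, gives in this assay < 15 mL.min-1.g-1, again a limit. Compound 1 sits at the limit of < 12 mL.min-1.g-1 in this assay, at which 1 of the 3 values shown sits, and compound 3 sits at the limit of < 15 mL.min-1.g-1 in this assay, at which 1 of the 3 values shown sits, so neither can be placed against compound 2 in order.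

The compound not yet measured is compound 4, `CC(C)CC[C@@H](O)C(=O)N1N=CC[C@H]1C(=O)NCc1cc(Cl)ccc1-n1cnnn1`. It differs from compound 2 in one place: isopentyl in place of 2-fluorophenyl on a saturated chain carbon bound to a carbonyl carbon and an oxygen on a saturated carbon. Within the data shown here, no measured pair shows the effect of such a change, so the size of the step can only be expected. With all three known results low, and with compound 1, which also carries a saturated chain on that carbon, at a limit of < 12 mL.min-1.g-1, the expected step is small, a 1.2-fold lower number from compound 2 to compound 4 (0.09 log units; within the scatter), no greater than the usual scatter and leaning, if anywhere, toward slower removal. Compound 4 is therefore estimated at 13 mL.min-1.g-1 in this assay, with a range from 7 mL.min-1.g-1 to 26 mL.min-1.g-1.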

Compound 4, intrinsic clearance in microsomes: 47 mL.min-1.g-1
Compound 4: the middle estimate sits 3.6-fold (0.56 log units) below what was measured, outside the stated range (above it).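

Among these compounds, at this position, on a saturated chain carbon bound to a carbonyl carbon and an oxygen on a saturated carbon, the new result gives the first readable step in this assay: isopentyl in place of 2-fluorophenyl brings a 2.9-fold higher number from compound 2 to compound 4 (0.47 log units; beyond the scatter). The earlier compounds shown here could not show this, as none of them differs from another in one place only, whereas here a single change on an otherwise shared core, from a six-membered aromatic ring of carbon only to an open chain with no ring, moves the read-out. The limits held by compound 1 and compound 3 cannot be read as steps, and nothing shown gives a cause for the change.

Going by these compounds, what stays open is whether the higher number goes with the open chain itself or with the loss of the aromatic ring and its fluorine. A cyclohexyl group or a shorter chain such as ethyl at this same place would be needed to tell these readings apart.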